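The source may report more compounds than this note shows. Statements on the series, on what has been measured and on what is new or still open speak of the compounds shown alone.

In a functional assay on MDA-MB-231 cells (Homo sapiens) for inhibition, read by sulforhodamine B assay, with a stated time of 48 h (a lower number here means a stronger inhibitor of growth, a higher number a weaker inhibitor of growth), compound 1 `COc1cc(-c2nn(-c3cccc(NC(=O)c4cccc(C(F)(F)F)c4)c3)cc2-c2ccncc2)ccc1Cl` gives 9960 nM, the higher of the two numbers in hand. Within the data shown here, compound 2 `O=C(Nc1cccc(-n2cc(-c3ccncc3)c(-c3ccc(Cl)c(O)c3)n2)c1)Nc1cc(C(F)(F)F)cc(C(F)(F)F)c1` gives 1660 nM in the same assay, a gap beyond the scatter, though compound 2 differs from compound 1 in more than one place, so no single step between measured compounds is available. Compound 3 `COc1cc(-c2nn(-c3cccc(NC(=O)Nc4ccc(Cl)c(Cl)c4)c3)cc2-c2ccncc2)ccc1Cl` differs from compound 1 by (3,4-dichlorophenyl)amino in place of 3-(trifluoromethyl)phenyl on a carbonyl carbon. A moderate move toward a lower number is expected, a 2.8-fold lower number from compound 1 to compound 3 (0.45 log units; beyond the scatter), since compound 2, which also carries a carbamoyl rather than a carbonyl link, sits at 1660 nM. For compound 3 the estimate is 3500 nM, with a range from 1200 nM to 10000 nM.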

Compound 3, concentration for total growth inhibition: 1920 nM
Compound 3: the middle estimate sits 1.8-fold (0.26 log units) above what was measured; the range from low to high includes it.
By their numbers in this assay, from the lowest: compounds 2 and 3 (each within the scatter of the next); then compound 1.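

In this assay, among these compounds, (3,4-dichlorophenyl)carbamoyl in place of (3-(trifluoromethyl)phenyl)carbonyl gives a 5.2-fold lower number from compound 1 to compound 3 (0.71 log units; beyond the scatter), the first single-place step and a modest one. This change replaces the ring substituents and adds the nitrogen with its hydrogen together, so the step cannot be divided between them. No measurement shown accounts for the step.

Still open, from the compounds shown here alone, is whether the gain follows the added nitrogen or the chlorines, which (3-(trifluoromethyl)phenyl)carbamoyl would separate. Also open, going by these compounds, is how cyclohexyl in place of the dichlorophenyl ring would read.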